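The source may hold more compounds than are shown below. What is called first, only, known or untested is meant among the compounds shown, and "the series" means these compounds.

Of the compounds shown here, two have been measured so far. Compound 1 `O=C(C1COc2ccccc2O1)N1N=C(c2ccc(Br)cc2)CC1c1cccc(F)c1` carries a 4-bromophenyl group on the shared core and, in a functional assay on WM 266-4 cells (Homo sapiens) for inhibition, read by MTT assay, with a stated time of 24 h (on this read-out higher numbers stand for weaker inhibition of growth and lower numbers for stronger inhibition of growth), compound 1 gives 7810 nM. Compound 2 `O=C(c1ccc2c(c1)OCCO2)N1N=C(c2ccccc2)CC1c1cccc(F)c1` differs in its carbonyl-bearing ring system and in carrying an unsubstituted phenyl group; in this assay compound 2 gives 1840 nM, the lower of the two numbers, and its gap to compound 1 lies beyond the usual scatter, so compound 2 inhibits growth more strongly than compound 1. Compound 1 and compound 2 differ in two places at once. Their two values do not isolate the effect of either change.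

Compound 3 `O=C(c1ccc2c(c1)OCCO2)N1N=C(c2ccc(Br)cc2)CC1c1cccc(F)c1` keeps the carbonyl-bearing ring system of compound 2 and introduces (bromo in place of hydrogen on an aromatic carbon). Within the data shown here, no single-change step among the measured compounds shows what this substitution does on this core, so the direction is open. The step from compound 2 to compound 3 is expected to be modest, a 1.4-fold higher number from compound 2 to compound 3 (0.15 log units; within the scatter), leaning toward weaker inhibition. In this assay compound 3 is therefore estimated at 2600 nM, with a plausible range from 800 nM to 8500 nM.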

Compound 3, concentration for 50% growth inhibition: 810 nM
For compound 3 the middle estimate is 3.2-fold (0.51 log units) above the measured one; measured number inside the range.
By their numbers in this assay, from the lowest: compound 3; then compound 2; then compound 1.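

In this assay, among these compounds, phenyl to 4-bromophenyl gives a 2.3-fold lower number from compound 2 to compound 3 (0.36 log units; beyond the scatter), the first reading of this change with nothing else altered: bromo in place of hydrogen on this aromatic carbon, para to a large group, goes with stronger inhibition of growth, not weaker. With the 4-bromophenyl group held fixed, 2,3-dihydro-1,4-benzodioxin-6-yl in place of 2,3-dihydro-1,4-benzodioxin-2-yl on the carbonyl carbon gives a 9.6-fold lower number from compound 1 to compound 3 (0.98 log units; beyond the scatter), so each of the two changes that separated compound 1 from compound 2 now has a single-change step of its own, and compound 3 stands as the strongest inhibitor of growth among the three. No measurement at hand accounts for either step.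

Going by these compounds, each step rests on one pair of compounds, so it remains open whether the bromo effect would also appear with the 2,3-dihydro-1,4-benzodioxin-2-yl group on the carbonyl carbon. On these data alone, it is equally open whether chloro, methoxy or an amine in place of the bromo would follow it, and what replacing the fluoro group shared by all three compounds would do.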